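Ethylamino to amino on a shared core

The source may report more compounds than this note shows. Statements on the series, on what has been measured and on what is new or still open speak of the compounds shown alone.

- compound 1 `CNC1=C(C)C(=O)C=C(C(C)C)C1=O` in a functional assay on A2780 cells (Homo sapiens) for inhibition, read by sulforhodamine B assay, with a stated time of 72 h (a higher number here means a weaker inhibitor, a lower number a stronger inhibitor), gives 14000 nM
- compound 2 `CCNC1=C(C)C(=O)C=C(C(C)C)C1=O` in this assay gives 12600 nM

Compound 2 and compound 1 stand within the scatter of each other, so neither can be ranked ahead. Compound 3 `CC1=C(N)C(=O)C(C(C)C)=CC1=O` has not yet been measured. It departs from compound 2 by hydrogen in place of ethyl on an amine nitrogen. Among the measured compounds shown here, only one measured step bears on this change, a 1.1-fold lower number from compound 1 to compound 2 (0.05 log units; within the scatter), which lengthened the same nitrogen substituent by a single methyl. Removing the substituent altogether is not covered by that step, so the evidence is thin. Even so, the one step available gives no reason to expect a shift beyond the scatter in this assay. The expected change is a 1.1-fold lower number from compound 2 to compound 3 (0.02 log units; within the scatter). Compound 3 is estimated at 12000 nM, within an expected range from 5000 nM to 28000 nM.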

Compound 3, half-maximal inhibitory concentration: 19900 nM
The estimate for compound 3 lay 1.7-fold (0.22 log units) below the measured number, and the stated range covers the measured number.
By their numbers in this assay, from the lowest: compounds 2, 1 and 3 (each within the scatter of the next).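

With the ethyl removed from the amine nitrogen, the free amino compound shows a 1.6-fold higher number from compound 2 to compound 3 (0.20 log units; within the scatter) and a 1.4-fold higher number from compound 1 to compound 3 (0.15 log units; within the scatter). Hydrogen, methyl and ethyl on this nitrogen therefore cannot be told apart in this assay, so the flat result now extends beyond a one-methyl change in chain length to removal of the alkyl substituent altogether. No measurement offers an explanation for this flat result.

Across these three compounds, the nitrogen carries only hydrogen or a short alkyl chain, so the effect of a longer chain such as butyl, or of an acetyl group on the same nitrogen, remains open. Going by these compounds, whether a carboxylic acid at the end of such a chain would move the number beyond the scatter also remains open.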